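Cyano for Methyl in a Corticotropin-Releasing Factor Series

The compounds below may be only part of what the source reports. "The series", "measured", "known", "first", "only" and "open" are said of these compounds alone.

Among the measured compounds shown here, compound 1 `COCc1cc(OC)c(-c2cccc3c(N(CC4CCOCC4)CC4CC4)c(C)nn23)c(OC)c1` is one of three compounds measured in an assay on HEK293 cells for displacement of a labelled ligand from corticotropin-releasing factor receptor 1 (Homo sapiens), read by scintillation counting, with a stated time of 2 h; a higher number here means a weaker inhibitor, a lower number a stronger inhibitor. In this assay compound 1 gives 120 nM, the highest of the three numbers. Compound 2 `CCc1nn2c(-c3c(C)cc(C)cc3OC)cccc2c1N(CCCF)CC1CC1` gives 20 nM in this assay, and compound 3 `CCc1nn2c(-c3c(OC)cc(C)cc3OC)cccc2c1N(CC1CCOCC1)CC1CC1` gives 22 nM; both gaps from compound 1 lie beyond the usual scatter, so compound 1 is the weakest inhibitor of the set as it stands. Compound 4 `COCc1cc(OC)c(-c2cccc3c(N(CC4CCOCC4)CC4CC4)c(C#N)nn23)c(OC)c1` has not yet been measured. It differs from compound 1 in one place: cyano in place of methyl on an aromatic carbon. For the measured compounds named here, no step between measured compounds bears on this change, so nothing in the three numbers says which way it should go. The expectation for compound 4 is a step that stays within the scatter, with no clear direction, giving an estimated 90 nM in this assay with a range from 30 nM to 300 nM. That estimate corresponds to an expected step of a 1.3-fold lower number from compound 1 to compound 4 (0.12 log units; within the scatter).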

Compound 4, half-maximal inhibitory concentration in the corticotropin-releasing factor receptor 1 assay: 52 nM
Beside the measured number, compound 4's estimate is 1.7-fold (0.24 log units) above it, and the stated range covers the measured number.
By their numbers in the corticotropin-releasing factor receptor 1 assay, from the lowest: compounds 2 and 3 (each within the scatter of the next); then compound 4; then compound 1.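

In the corticotropin-releasing factor receptor 1 assay, the step of a 2.3-fold lower number from compound 1 to compound 4 (0.36 log units; beyond the scatter) shows that this position, on the five-membered aromatic ring, is not silent: cyano in place of methyl moves the number beyond the scatter, towards a stronger inhibitor. In a physicochemical assay for solubility, in phosphate buffer, measured as kinetic solubility (a higher number here means a more soluble compound, a lower number a less soluble compound), compound 1 gives 21000 nM and compound 4 gives 1700 nM, and that step, a 12-fold lower number from compound 1 to compound 4 (1.09 log units; beyond the scatter), is the larger of the two. Cyano for methyl here thus pairs a modest gain in inhibition with a large loss of solubility: the measured solubility of compound 1, 21000 nM, and of compound 4, 1700 nM, a 12-fold lower number (1.09 log units; beyond the scatter)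

Among the compounds shown here, only this one pair carries the change, so whether it holds for other compounds remains open. Also open, from the compounds shown here alone, is whether another group here, such as an amine or a carboxamide, would keep the lower number in the corticotropin-releasing factor receptor 1 assay without the fall in the physicochemical assay.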